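Side chain change from compound 3 to compound 4

A few compounds are considered here, and "the series" means these few. Any claim that something is new, unique, unknown or untested is made for them only; others in the source may bear on it.

Measured so far in a physicochemical assay for solubility, in phosphate buffer, with a stated time of 18 h, at pH 7.4 (a lower number here means a less soluble compound, a higher number a more soluble compound), for this series:
- compound 1 `COc1cc2ncnc(-n3nc(-c4ccccn4)nc3N)c2cc1OCc1ccccc1` gives 58000 nM as its value
- compound 2 `COc1cc2c(-n3nc(-c4ccccn4)nc3N)ncnc2cc1OCc1ccccc1` gives 68000 nM as its value
- compound 3 `CCN(CC)C(=O)COc1cc2c(-n3nc(-c4ccccn4)nc3N)ncnc2cc1OC` gives 42000 nM as its value

The three values lie within the scatter of one another, so compound 3 is not separated from compound 1 or compound 2 on these numbers. Compound 4 `CCOC(=O)NCCCOc1cc2c(-n3nc(-c4ccccn4)nc3N)ncnc2cc1OC` comes from compound 3 through 2-((ethoxycarbonyl)amino)ethyl in place of diethylcarbamoyl on a saturated chain carbon bound to an oxygen on an aromatic ring as the one structural difference. Cut one bond further out, this reads (diethylcarbamoyl)methyl to 3-((ethoxycarbonyl)amino)propyl.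

Among the compounds with values here, one measured step bears on this place, a 1.4-fold lower number from compound 1 to compound 3 (0.14 log units; within the scatter) as the only evidence, and it brought in diethylcarbamoyl in place of phenyl. Within the data shown here, no measurement yet covers the entering group, so this single step is a thin guide. From it, no step beyond the scatter is expected in this assay in either direction. The estimated step is a 1.1-fold lower number from compound 3 to compound 4 (0.02 log units; within the scatter) on that reading. The estimated value for compound 4 is 40000 nM with an expected range of 16000 nM to 90000 nM at this stage.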

Compound 4, solubility: 16000 nM
The estimate for compound 4 lay 2.5-fold (0.40 log units) above the measured number; low and high end bracket the measured number.
By their numbers in this assay, from the lowest: compound 4; then compounds 3, 1 and 2 (each within the scatter of the next).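

In this assay, the place on a saturated chain carbon bound to an oxygen on an aromatic ring now shows a change beyond the scatter: 2-((ethoxycarbonyl)amino)ethyl gives a lower number in place of diethylcarbamoyl (a 2.6-fold lower number from compound 3 to compound 4 (0.42 log units; beyond the scatter)) and in place of phenyl (a 3.6-fold lower number from compound 1 to compound 4 (0.56 log units; beyond the scatter)). The earlier step at this place, diethylcarbamoyl in place of phenyl, stayed within the scatter (a 1.4-fold lower number from compound 1 to compound 3 (0.14 log units; within the scatter)), so this position is not indifferent to every group placed on it. Nothing measured here accounts for the lower number of compound 4.

Open, from the compounds shown here alone, is whether the step follows the ethoxycarbonylamino end or the length of the chain that carries it. A 3-aminopropyl or 3-hydroxypropyl group, or a carboxylic acid on the same chain, would separate these two readings.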